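Trimethoxyphenyl swapped for 4-fluorophenyl in a growth-inhibition series

The source may hold more compounds than are shown below. What is called first, only, known or untested is meant among the compounds shown, and "the series" means these compounds.

Measured in a functional assay on A549 cells (Homo sapiens) for inhibition, read by sulforhodamine B assay, with a stated time of 48 h; on this read-out higher numbers stand for weaker inhibition of growth and lower numbers for stronger inhibition of growth:
- compound 1 (`COc1ccc(/C=C/C(=O)/C=C/c2cc(OC)c(OC)c(OC)c2)cc1OC`): 1210 nM
- compound 2 (`COc1ccc(/C=C/C(=O)C(=Cc2ccc(O)c(OC)c2)C(=O)/C=C/c2ccc(OC)cc2)cc1`): 1640 nM
- compound 3 (`COc1ccc(/C=C/C(=O)C(=Cc2cc(OC)c(OC)c(OC)c2)C(=O)/C=C/c2ccc(OC)c(OC)c2)cc1OC`): 230 nM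

Compound 3 (230 nM) gives the lowest number of the three, and its gaps to compound 1 and compound 2 both lie beyond the usual scatter. The next compound, compound 4 (`COc1ccc(/C=C/C(=O)C(=Cc2ccc(F)cc2)C(=O)/C=C/c2ccc(OC)c(OC)c2)cc1OC`), departs from compound 3 in one place: 4-fluorophenyl in place of 3,4,5-trimethoxyphenyl on a double-bonded chain carbon bound to a double-bonded chain carbon.

For the measured compounds named here, no measured pair isolates this change, so the evidence is indirect. Compound 2 (1640 nM) also lacks the 3,4,5-trimethoxyphenyl group, but it differs from compound 3 in other places too. Compound 1 (1210 nM) goes against any simple link between that group and a low number, since it carries the group and still sits well above compound 3. A moderate step toward weaker inhibition of growth in this assay is therefore expected, estimated as (a 2.3-fold higher number from compound 3 to compound 4 (0.35 log units; beyond the scatter)). The estimated value for compound 4 is (520 nM), with an expected range from (170 nM) to (1500 nM).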

Compound 4, concentration for 50% growth inhibition: 550 nM
For compound 4 the middle estimate is 1.1-fold (0.02 log units) below the measured one; measured number inside the range.
By their numbers in this assay, from the lowest: compound 3; then compound 4; then compounds 1 and 2 (each within the scatter of the next).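

In this assay, for the compounds shown here, the change from 3,4,5-trimethoxyphenyl to 4-fluorophenyl on a double-bonded chain carbon bound to a double-bonded chain carbon gives a 2.4-fold higher number from compound 3 to compound 4 (0.38 log units; beyond the scatter), the first direct reading of this position and a modest step. The position therefore tolerates the loss of 3,4,5-trimethoxyphenyl without the full loss of growth inhibition: the entering group has fewer heavy atoms and fewer hydrogen-bond acceptors than the leaving group, yet compound 4 still gives 550 nM. Nothing measured here accounts for the size of this step, and this single pair shows no trend.

The compounds shown leave open how much of the step belongs to the fluorine and how much to the three methoxy groups, and a plain phenyl or a 3,4-dimethoxyphenyl at this place would help to separate the two. Also open, as far as these compounds go, is whether a ring carrying a dimethylamino group or a carboxylic acid would be tolerated at this position as 4-fluorophenyl is.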